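This account rests on a few compounds, and the source may have more. Where it says the series, first, only, none or still open, it means among the compounds named here.

Three analogues built on one shared core were examined for their effect on cell growth. Compound 1 `CCCCNC(=O)C1C(C(=O)O)[C@@H]2CC[C@H]1O2` carries a butyl chain on the amide nitrogen, compound 2 `O=C(O)CCCNC(=O)C1C(C(=O)O)[C@@H]2CC[C@H]1O2` a 3-carboxypropyl chain, and compound 3 `O=C(O)CCCCCCCNC(=O)C1C(C(=O)O)[C@@H]2CC[C@H]1O2` a 7-carboxyheptyl chain. In an ADME assay on SW480 cells (Homo sapiens) for cytotoxicity, read by MTT assay, with a stated time of 72 h (a lower number here means a stronger inhibitor of growth, a higher number a weaker inhibitor of growth), compound 1 gives 10000 nM, compound 2 gives 10000 nM and compound 3 gives 10000 nM. The three values sit together: the step of no change at the digits printed from compound 2 to compound 1 (within the scatter), the step of no change at the digits printed from compound 1 to compound 3 (within the scatter) and the step of no change at the digits printed from compound 2 to compound 3 (within the scatter) are all flat within the scatter of this assay.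

Compound 4 `CCCCCCCCNC(=O)C1C(C(=O)O)[C@@H]2CC[C@H]1O2` differs from compound 3 by methyl in place of carboxy on a saturated chain carbon, seven bonds along the chain from an amide-type nitrogen. The same kind of change has already been measured, from compound 2 to compound 1, as methyl in place of carboxy on a saturated chain carbon, three bonds along the chain from an amide-type nitrogen, and there it produced no change at the digits printed from compound 2 to compound 1 (within the scatter). The two cores on which this change is made differ by 4-carboxybutyl in place of carboxy on a saturated chain carbon, three bonds along the chain from an amide-type nitrogen, and the place differs as well: in the measured pair the change sits three bonds along the chain from the amide-type nitrogen, whereas in compound 4 it sits seven bonds along the chain, so it is the same kind of change rather than the same change.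

Given that every measured step is flat, the step from compound 3 to compound 4 is expected to be no change at the digits printed from compound 3 to compound 4 (within the scatter), resting on the flat no change at the digits printed from compound 2 to compound 1 (within the scatter) for the same kind of change. Compound 4 is therefore estimated at 10000 nM, with a range from 4000 nM to 25000 nM.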

Compound 4, concentration for 50% growth inhibition: 10000 nM
For compound 4 middle estimate and measured number coincide at the digits printed; measured number inside the range.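

In this assay, putting methyl in place of carboxy on a saturated chain carbon, seven bonds along the chain from an amide-type nitrogen, gives no change at the digits printed from compound 3 to compound 4 (within the scatter), and the other two steps that reach the new compound read the same way, with no change at the digits printed from compound 2 to compound 4 (within the scatter) and no change at the digits printed from compound 1 to compound 4 (within the scatter). Set beside the earlier case of this change, the result shows that it behaves alike on the two cores: the same change on two cores in this assay, no change at the digits printed (within the scatter) from compound 2 to compound 1 and no change at the digits printed (within the scatter) from compound 3 to compound 4, 1.0-fold (0.00 log units) apart, within the scatter of two such steps This agreement is only between two flat steps, at two places on the chain, so it does not show that the change would carry over with the same size on a core where it moved the number, and it gives no sign of what in these structures sets the shared level.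

Among these compounds, all four compounds stand level, so the comparison offers no step of any size against which a transfer could really be tested. Going by these compounds, it remains open whether an amine or a hydroxyl at the end of the chain, a longer chain, or an ester in place of the carboxylic acid on the shared core would move growth inhibition away from this level.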